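A few compounds are considered here, and "the series" means these few. Any claim that something is new, unique, unknown or untested is made for them only; others in the source may bear on it.

Compound 3 `CCCCCCCCCCCO[C@@H]1[C@@H](O)[C@H](O[C@H]2O[C@H](CN)[C@@H](O)[C@H](OCCCCCCC)[C@H]2N)[C@@H](N)C[C@H]1N` carries both an undecyl and a heptyl chain on its core, and in an ADME assay on J774 cells (Mus musculus) for cytotoxicity, read by MTT assay, with a stated time of 24 h, tested at 30 uM (a higher number here means a weaker effect of the compound at the concentration tested, a lower number a stronger effect), compound 3 gives 38.8%, the lowest of the three numbers measured. Its nearest neighbour is compound 1 `CCCCCCCCCCCO[C@@H]1[C@@H](N)[C@@H](O[C@H]2[C@H](O)[C@@H](OCCCCCCC)[C@H](N)C[C@@H]2N)O[C@H](CN)[C@H]1O`, for which 39.1% was recorded, a value within the scatter of compound 3. The furthest is compound 2 `CCCCCCCO[C@@H]1[C@@H](O)[C@H](O[C@H]2O[C@H](CN)[C@@H](O)[C@H](O)[C@H]2N)[C@@H](N)C[C@H]1N`, for which this assay gave 71.3%, well beyond the scatter.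

Compound 4 `CCCCCCCO[C@@H]1[C@@H](N)[C@@H](O[C@H]2[C@H](O)[C@@H](OCCCCCCC)[C@H](N)C[C@@H]2N)O[C@H](CN)[C@H]1O` is reached from compound 3 by hydrogen in place of butyl on a saturated chain carbon, seven bonds along the chain from an oxygen on a saturated carbon, so that the undecyl chain becomes a heptyl chain. Going by the values given here, the one measured step that bears on this is a number 32.2 percentage points higher from compound 1 to compound 2 (beyond the scatter), where the whole undecyl chain was removed. Shortening the chain by a butyl rather than removing it altogether is expected to move this assay in the same direction, but by less, so a moderate rise beyond the scatter is anticipated for compound 4, estimated as a number 13.2 percentage points higher from compound 3 to compound 4 (beyond the scatter). For compound 4 the estimate in this assay is therefore 52%, with an expected range of 40% to 65%.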

Compound 4, a percentage reported as activity, at one concentration (the size of the read-out at that concentration, not a potency): 79.9%
Compound 4: the middle estimate sits 27.9 percentage points below what was measured, outside the stated range (above it).
By their numbers in this assay, from the lowest: compounds 3 and 1 (each within the scatter of the next); then compounds 2 and 4 (each within the scatter of the next).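

In this assay, hydrogen in place of butyl, which turns the undecyl chain into a heptyl chain, gives a number 41.1 percentage points higher from compound 3 to compound 4 (beyond the scatter) and a number 40.8 percentage points higher from compound 1 to compound 4 (beyond the scatter), so this shortening alone has a large effect on the read-out. Where the earlier compounds showed only the loss of the whole undecyl chain, heptyl in place of hydrogen on an oxygen on a saturated carbon now gives a number 8.6 percentage points higher from compound 2 to compound 4 (within the scatter). Among these compounds, a heptyl chain at this position therefore reads like no chain at all, and the large change lies between heptyl and undecyl.

Nothing given here explains why the butyl portion matters so much. From the compounds shown here alone, whether an octyl or nonyl chain would read like compound 4 or like compound 3 remains open, as does the effect of a chain longer than undecyl.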